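Repeating the aryl swap on a second linker

A few compounds are considered here, and "the series" means these few. Any claim that something is new, unique, unknown or untested is made for them only; others in the source may bear on it.

Within the data shown here, compound 3 `Cc1c(OC[C@@H](C)COc2ccc(Cl)c(C(=O)O)c2)ccc(C(=O)CC(C)(C)C)c1O` gives 377 nM in an assay for positive allosteric modulation of metabotropic glutamate receptor 2 (Rattus norvegicus) (on this read-out higher numbers stand for an effect only at larger amounts of compound and lower numbers for an effect already at smaller amounts), the highest of the three numbers measured so far. Compound 1 `Cc1c(OCCCCOc2ccc(Cl)c(C(=O)O)c2)ccc(C(=O)CC(C)(C)C)c1O` gives 87 nM and compound 2 `Cc1c(OCCCCOc2ccc(C(=O)O)c(F)c2)ccc(C(=O)CC(C)(C)C)c1O` gives 80 nM, both beyond the scatter from compound 3. Compound 4 `Cc1c(OC[C@@H](C)COc2ccc(C(=O)O)c(F)c2)ccc(C(=O)CC(C)(C)C)c1O` has not been measured; it differs from compound 3 by 4-carboxy-3-fluorophenyl in place of 3-carboxy-4-chlorophenyl on an oxygen on a saturated carbon. The same exchange has been made once already, between compound 1 and compound 2: a 1.1-fold lower number from compound 1 to compound 2 (0.04 log units; within the scatter). That step bears directly on the present one and lies within the scatter, so for compound 4 no step beyond the scatter is expected in this assay, only a 1.1-fold lower number from compound 3 to compound 4 (0.03 log units; within the scatter). Compound 4 is therefore estimated at 350 nM, with a range from 180 nM to 700 nM.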

Compound 4, half-maximal effective concentration: 261 nM
Beside the measured number, compound 4's estimate is 1.3-fold (0.13 log units) above it; the range from low to high includes it.
By their numbers in this assay, from the lowest: compounds 2 and 1 (each within the scatter of the next); then compounds 4 and 3 (each within the scatter of the next).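

On the second linker, the exchange of 3-carboxy-4-chlorophenyl for 4-carboxy-3-fluorophenyl again stays within the scatter (a 1.4-fold lower number from compound 3 to compound 4 (0.16 log units; within the scatter)). The earlier pair alone could not show whether this held on more than one core. In this assay, the two groups now give matching results on both linkers, and the two steps agree: the same change on two cores in this assay, a 1.1-fold lower number (0.04 log units; within the scatter) from compound 1 to compound 2 and a 1.4-fold lower number (0.16 log units; within the scatter) from compound 3 to compound 4, 1.3-fold (0.12 log units) apart, within the scatter of two such steps

Going by these compounds, whether the exchange stays this small on a longer chain remains open. So does whether a tetrazole in place of the carboxylic acid would hold the number on either core.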